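A few compounds are considered here, and "the series" means these few. Any claim that something is new, unique, unknown or untested is made for them only; others in the source may bear on it.

Measured compounds:
- compound 1, `CC1(C)COC(=O)[C@@H]1OC(=O)c1ccccc1`, 23000 nM in an assay on isolated protein for inhibition of fatty acid synthase (Mus musculus), read by spectrophotometry, using NADPH, with stated times of 30 min and 3 min, in the presence of a further agent that is not named here; on this read-out higher numbers stand for weaker inhibition and lower numbers for stronger inhibition
- compound 2, `COc1ccc(C(=O)O[C@H]2C(=O)OCC2(C)C)cc1`, 13700 nM in this assay

Both measured compounds share one core, a small lactone ring bearing a benzoate ester, and differ only in the group on the aromatic ring. In this assay compound 1 gives 23000 nM, and compound 2 gives 13700 nM. The single step between them, a 1.7-fold lower number from compound 1 to compound 2 (0.23 log units; within the scatter), lies within the scatter of repeated measurements, so the two numbers cannot be told apart with confidence; compound 2 simply stands next to compound 1 on the numbers shown.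

Compound 3, `Cc1ccc(C(=O)O[C@H]2C(=O)OCC2(C)C)cc1`, has not yet been measured. It differs from compound 2 in one place: methyl in place of methoxy on an aromatic carbon. Among the measured compounds shown here, the only step that bears on this change is the one from hydrogen to methoxy on the same aromatic carbon, which was within the scatter. With no step beyond the scatter on this position, the expectation for compound 3 in this assay is a step of about a 1.1-fold higher number from compound 2 to compound 3 (0.04 log units; within the scatter), that is, nothing beyond the scatter. Compound 3 is therefore estimated at 15000 nM, with a range from 6000 nM to 40000 nM.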

Compound 3, half-maximal inhibitory concentration: 17200 nM
For compound 3 the middle estimate is 1.1-fold (0.06 log units) below the measured one, and the stated range covers the measured number.
By their numbers in this assay, from the lowest: compounds 2, 3 and 1 (each within the scatter of the next).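

In this assay, replacing methoxy with methyl on this aromatic carbon gives a 1.3-fold higher number from compound 2 to compound 3 (0.10 log units; within the scatter), and replacing hydrogen with methyl on the same carbon gives a 1.3-fold lower number from compound 1 to compound 3 (0.13 log units; within the scatter). Hydrogen, methoxy and methyl can therefore no longer be told apart at this place, even though the change from methoxy to methyl removes an oxygen and a hydrogen-bond acceptor, which extends the earlier finding from a single substitution to a set of three groups. No separate measurement is available that could say why these numbers stay so close.

The compounds shown leave open whether any group on this aromatic carbon can move the number beyond the scatter, since the only groups compared here are hydrogen, methoxy and methyl. From the compounds shown here alone, an amine, a carboxylic acid or a longer chain such as butoxy in this place would put that question to a sharper test, and it also remains open how much a change elsewhere on the shared core, which is the same in all three compounds, would matter.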